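The compounds below may be only part of what the source reports. "The series", "measured", "known", "first", "only" and "open" are said of these compounds alone.

- Compound 1 `CC(C)=CCC/C(C)=C/CC/C(C)=C/CSC[C@H](NC(=O)CCCCCN1CCN(C)CC1)C(=O)NC1CCCCCC1`: 6200 nM
- Compound 2 `CC(C)=CCC/C(C)=C/CC/C(C)=C/CSC[C@H](NC(=O)CCCCCN1CCCC1)C(=O)NC1CCCCCC1`: 5800 nM

Within the data shown here, in a functional assay on BXPC-3 cells (Homo sapiens) for cytotoxicity, read by fluorescence, with a stated time of 48 h (on this read-out lower numbers stand for an effect already at smaller amounts and higher numbers for an effect only at larger amounts of compound), compound 1 gives 6200 nM and lies within the scatter of compound 2, the only other compound measured. Compound 3 `CC(C)=CCC/C(C)=C/CC/C(C)=C/CSC[C@H](NC(=O)CCCCCN1CCN(C)CC1)C(=O)NC1CCCCC1` differs from compound 1 by cyclohexyl in place of cycloheptyl on an amide-type nitrogen in that cyclohexyl takes the place of cycloheptyl on an amide-type nitrogen. Among the measured compounds shown here, the one measured step is a 1.1-fold lower number from compound 1 to compound 2 (0.03 log units; within the scatter) and it replaces 4-methylpiperazin-1-yl rather than cycloheptyl, so nothing measured tests this change directly. For the measured compounds named here, with only that small step as a guide, the expected step is a 1.0-fold higher number from compound 1 to compound 3 (0.02 log units; within the scatter) and no shift beyond the scatter is expected. For compound 3 the estimated value is 6500 nM with an expected range from 3000 nM to 14000 nM in this measurement.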

Compound 3, half-maximal effective concentration: 12000 nM
Estimate against measurement, compound 3: 1.8-fold (0.27 log units) below; the measured number falls inside the stated range.
By their numbers in this assay, from the lowest: compounds 2, 1 and 3 (each within the scatter of the next, the first and the last beyond it).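

Changing the ring on the amide-type nitrogen from cycloheptyl to cyclohexyl gives a 1.9-fold higher number from compound 1 to compound 3 (0.29 log units; within the scatter) in this assay and so provides the first direct test of this position. Even so, the step stays within the scatter, so this swap from a seven-membered to a six-membered ring shows no real effect on the read-out. No supporting measurement bears on this result. Still open, going by these compounds, is whether a cyclopentyl or phenyl group on this nitrogen would move the number beyond the scatter. Also open, on these data alone, is how pyrrolidin-1-yl behaves alongside cyclohexyl.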